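Ester variation on a hydroxyimino core: compound 4 expected

This account rests on a few compounds, and the source may have more. Where it says the series, first, only, none or still open, it means among the compounds named here.

Compound 3 `COc1ccc(C2CC(=NOC(=O)c3ccccc3O)CC(c3ccc(OC)cc3)N2C)cc1` gives 29000 nM in a functional assay, with a stated time of 30 min (a higher number here means a weaker inhibitor, a lower number a stronger inhibitor), and so holds the lowest number of the three measured compounds, sitting beyond the scatter from both of its relatives. Compound 1 `COc1ccc(C2CC(=NO)CC(c3ccc(OC)cc3)N2C)cc1` gives 380000 nM, and compound 2 `COc1ccc(C2CC(=NOC(=O)c3ccc(Cl)cc3)CC(c3ccc(OC)cc3)N2C)cc1` gives 135000 nM; the steps of a 2.8-fold lower number from compound 1 to compound 2 (0.45 log units; beyond the scatter) and a 13-fold lower number from compound 1 to compound 3 (1.12 log units; beyond the scatter) show that acylating the oxygen lowered the number in both cases, and the step of a 4.7-fold lower number from compound 2 to compound 3 (0.67 log units; beyond the scatter) shows that the choice of aryl group on the carbonyl carbon moved the number further. Compound 4 `COc1ccc(C2CC(=NOC(=O)c3cc(O)cc(O)c3)CC(c3ccc(OC)cc3)N2C)cc1` differs from compound 3 by the change (3,5-dihydroxyphenyl in place of 2-hydroxyphenyl on a carbonyl carbon). Going by the values given here, the only measured step that exchanges the aryl group on that carbonyl carbon is the modest one from compound 2 to compound 3, so a step of similar or smaller size is expected here, with its direction open. Compound 4 is therefore estimated at 20000 nM, between 5000 nM and 80000 nM, which means the expected step of a 1.5-fold lower number from compound 3 to compound 4 (0.16 log units; within the scatter).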

Compound 4, half-maximal inhibitory concentration: 19000 nM
For compound 4 the middle estimate is 1.1-fold (0.02 log units) above the measured one, within the range that was stated.
By their numbers in this assay, from the lowest: compounds 4 and 3 (each within the scatter of the next); then compound 2; then compound 1.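

In this assay, the 3,5-dihydroxyphenyl and 2-hydroxyphenyl esters cannot be told apart, with a 1.5-fold lower number from compound 3 to compound 4 (0.18 log units; within the scatter) as the only difference, so this position on the carbonyl carbon accepts this exchange of aryl groups without a readable change. Compared with the 4-chlorophenyl ester, the new group gives a 7.1-fold lower number from compound 2 to compound 4 (0.85 log units; beyond the scatter) and so joins 2-hydroxyphenyl in lying beyond the scatter from compound 2. Placing (3,5-dihydroxyphenyl)carbonyl in place of hydrogen on the oxygen gives a 20-fold lower number from compound 1 to compound 4 (1.30 log units; beyond the scatter) as the largest step in this small set.

As far as these compounds go, how an unsubstituted phenyl, an aminophenyl or a carboxylic acid on the aryl ring would compare stays open, as does whether an amide in place of the ester link would keep these numbers. No available evidence accounts for the numbers these aryl groups give.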